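The source may hold more compounds than are shown below. What is called first, only, known or untested is meant among the compounds shown, and "the series" means these compounds.

Measured in a functional assay on MCF7 cells (Homo sapiens) for cytotoxicity, in the presence of a further agent that is not named here; on this read-out higher numbers stand for an effect only at larger amounts of compound and lower numbers for an effect already at smaller amounts
- compound 1 `CCCCCCCO[C@@H]1[C@@H](O)[C@@H](OCc2ccccc2)O[C@H](CC(C)C)[C@H]1OC` gives 7 ug/mL
- compound 2 `CCCCCCCO[C@@H]1[C@@H](O)[C@@H](OCc2ccccc2)O[C@H](CC(C)C)[C@H]1OCc1ccc(OC)cc1` gives 4 ug/mL
- compound 3 `CCCCCCCO[C@@H]1[C@@H](O)[C@@H](OCc2ccccc2)O[C@H](CC(C)C)[C@H]1O` gives 6 ug/mL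

Compound 1 stands within the scatter of both other compounds, and these two also lie within the scatter of each other. Compound 4 `CCCCCCCO[C@@H]1[C@@H](OCc2ccccc2)[C@@H](OCc2ccccc2)O[C@H](CC(C)C)[C@H]1OC` differs from compound 1 at the free hydroxy, which becomes benzyloxy: benzyl in place of hydrogen on an oxygen on a saturated carbon. Among the measured compounds shown here, no measured step touches this hydroxy, so the evidence is indirect. All three steps change another oxygen, and a 1.8-fold lower number from compound 1 to compound 2 (0.24 log units; within the scatter), a 1.2-fold lower number from compound 1 to compound 3 (0.07 log units; within the scatter) and a 1.5-fold higher number from compound 2 to compound 3 (0.18 log units; within the scatter). Even the 4-methoxybenzyl group of compound 2 gave no step beyond the scatter. No step beyond the scatter is therefore expected in this assay, and no direction can be favoured. The expected step is a 1.2-fold lower number from compound 1 to compound 4 (0.07 log units; within the scatter). Compound 4 is estimated at 6 ug/mL, with an expected range of 2.5 ug/mL to 14 ug/mL.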

Compound 4, half-maximal effective concentration: > 20 ug/mL
Compound 4 ended at the assay's limit; the forecaster's own chance of this, stated with the estimate: 10%; at least 3.3-fold (0.52 log units) between middle value and limit.
By their numbers in this assay, from the lowest: compounds 2, 3 and 1 (each within the scatter of the next). At a limit, above all of these: compound 4.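

In this assay, among the compounds shown here, the free hydroxy is the first position here where a change reaches beyond the scatter, with benzyl in place of hydrogen on this oxygen giving an at least 2.8-fold higher number from compound 1 to compound 4 (0.45 log units; beyond the scatter). On the other oxygen, hydrogen, methyl and 4-methoxybenzyl all stayed within the scatter of each other. The value of compound 4 is a limit of the assay, not a number: the limit of > 20 ug/mL in this assay, at which 1 of the 4 values shown sits.

The compounds shown leave open whether the free hydroxy itself matters or only the benzyl group does. A methyl or acetyl group on this oxygen would separate the two.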